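Sulfonamide series: cytotoxicity notes ahead of compound 4

A few compounds are considered here, and "the series" means these few. Any claim that something is new, unique, unknown or untested is made for them only; others in the source may bear on it.

Measured in an ADME assay on HEK293 cells (Homo sapiens) for cytotoxicity, read by resazurin assay, with a stated time of 48 h (on this read-out higher numbers stand for lower toxicity in this test and lower numbers for higher toxicity in this test), so far:
Compound 1 `O=S(=O)(Nc1ccc2oc(-c3ccccc3)nc2c1)c1ccccc1Cl` gives 73000 nM.
Compound 2 `O=S(=O)(Nc1ccc2oc(-c3ccccc3)nc2c1)c1ccc(Cl)c(C(F)(F)F)c1` gives 66000 nM.
Compound 3 `Cc1ccc(S(=O)(=O)Nc2ccc3oc(-c4ccccc4)nc3c2)cc1` gives 75000 nM.

On the bare numbers compound 3 sits at the top of the three, but this says little: the step of a 1.0-fold higher number from compound 1 to compound 3 (0.01 log units; within the scatter) is within the scatter, and the values of compound 3 and compound 2 also differ by less than the scatter, so the three compounds are not separated in this assay.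

Compound 4 `O=S(=O)(Nc1ccc2oc(-c3ccccc3)nc2c1)c1ccc(Cl)cc1` is the next member. It differs from compound 3 as follows: chloro in place of methyl on an aromatic carbon.

Among the compounds with values here, the only measured step that bears on an exchange at the aryl group on the sulfonyl sulfur is a 1.0-fold higher number from compound 1 to compound 3 (0.01 log units; within the scatter), which swapped one substituted phenyl for another with no change beyond the scatter. Compound 2, carrying a further pattern on that ring, likewise gives a value within the scatter of compounds 1 and 3. Within the data shown here, nothing measured so far suggests that a change on this ring moves the read-out in this assay, and the exchange of methyl for chloro is expected to behave the same way, giving a step of a 1.1-fold lower number from compound 3 to compound 4 (0.03 log units; within the scatter) that stays within the scatter.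

Compound 4 is therefore estimated at 70000 nM in this assay, with a range from 42000 nM to 115000 nM.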

Compound 4, half-maximal cytotoxic concentration: 65000 nM
For compound 4 the middle estimate is 1.1-fold (0.03 log units) above the measured one, within the range that was stated.
By their numbers in this assay, from the lowest: compounds 4, 2, 1 and 3 (each within the scatter of the next).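

In this assay, chloro in place of methyl at the position para to a large group gives a 1.2-fold lower number from compound 3 to compound 4 (0.06 log units; within the scatter), within the scatter, so this single-atom exchange does not separate the two compounds. Within the data shown here, compound 4 also adds two comparisons that the earlier compounds did not offer: 4-chlorophenyl in place of 2-chlorophenyl gives a 1.1-fold lower number from compound 1 to compound 4 (0.05 log units; within the scatter), and hydrogen in place of trifluoromethyl gives a 1.0-fold lower number from compound 2 to compound 4 (0.01 log units; within the scatter), both again within the scatter, so neither the place of the chloro on this ring nor the trifluoromethyl group separates these compounds. No supporting measurement is available to account for these small steps.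

Going by these compounds, the substituents compared on this ring are only methyl, chloro and trifluoromethyl, so it remains open whether an amine or a carboxylic acid there, or a longer alkyl chain in place of the whole aryl group on the sulfonyl sulfur, would move the read-out in this assay beyond the scatter. The shared core and its phenyl group are the same in all four compounds, so these values say nothing about how changes at those parts would read in this test.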